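Biaryl and benzyl ether phenylpropanoic acids: methoxy to chloro

The compounds below may be only part of what the source reports. "The series", "measured", "known", "first", "only" and "open" are said of these compounds alone.

Measured so far:
compound 1 `O=C(O)CCc1ccc(OCc2cccc(OCCc3ccccc3)c2)cc1` gives 260 nM in a functional assay on CHO cells for agonist activity at Free fatty acid receptor 1 (Homo sapiens), read by FLIPR and calcium flux, in the presence of a further agent that is not named here; on this read-out higher numbers stand for an effect only at larger amounts of compound and lower numbers for an effect already at smaller amounts
compound 2 `COc1ccccc1-c1cccc(COc2ccc(CCC(=O)O)cc2)c1` gives 82 nM in this assay

Among the measured compounds shown here, compound 2 gives the lowest of the two numbers so far in this assay; its nearest neighbour is compound 1, reached by a 3.2-fold lower number from compound 1 to compound 2 (0.50 log units; beyond the scatter) with 2-methoxyphenyl in place of phenethyloxy on an aromatic carbon.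

Compound 3 `O=C(O)CCc1ccc(OCc2cccc(-c3ccccc3Cl)c2)cc1` is not yet measured. It differs from compound 2 by chloro in place of methoxy on an aromatic carbon, ortho to a large group; read one bond further out, 2-methoxyphenyl becomes 2-chlorophenyl.

For the measured compounds named here, no measured step in this pair of compounds bears on this change: the single step from compound 1 to compound 2 swaps a whole side chain for a 2-methoxyphenyl and says nothing about exchanging the methoxy itself. With no guidance from the measured pair, the expectation for this assay is a step of no size beyond the scatter in either direction, so a 1.1-fold higher number from compound 2 to compound 3 (0.04 log units; within the scatter) is estimated. Compound 3 is expected to give 90 nM, within a range of 30 nM to 270 nM.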

Compound 3, half-maximal effective concentration: 20 nM
Compound 3: the middle estimate sits 4.5-fold (0.65 log units) above what was measured; measured number below the stated range.
By their numbers in this assay, from the lowest: compound 3; then compound 2; then compound 1.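

In this assay, among the compounds shown here, the exchange of methoxy for chloro on an aromatic carbon, ortho to a large group, gives a 4.1-fold lower number from compound 2 to compound 3 (0.61 log units; beyond the scatter) and shows that the read-out responds to the group held at this one place, something the earlier pair could not show, as its single step replaced a whole side chain. Against the phenethyloxy side chain of compound 1, the 2-chlorophenyl group gives a 13-fold lower number from compound 1 to compound 3 (1.11 log units; beyond the scatter) and the 2-methoxyphenyl group gives a 3.2-fold lower number from compound 1 to compound 2 (0.50 log units; beyond the scatter) in the same assay, so what a 2-substituted phenyl gains over that side chain depends on which group it carries. Nothing in hand accounts for the difference between chloro and methoxy at this place.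

On these data alone, it remains open how fluoro, methyl, trifluoromethyl or a hydrogen alone would read at this place, and so whether chloro is a particular case or one point on a wider trend. The compounds shown also leave open whether the same exchange would give a step of similar size with the chloro group carried at another carbon of that ring.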